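The compounds below may be only part of what the source reports. "The series", "measured", "known", "first", "only" and "open" are said of these compounds alone.

In a functional assay on MDA-MB-231 cells (Homo sapiens) for antiproliferative activity, with a stated time of 4 days (on this read-out higher numbers stand for weaker inhibition and lower numbers for stronger inhibition), compound 1 `CCCCc1ccc2[nH]c(-c3ccc(OC)cc3)c(/C=N/O)c2c1` gives 40 nM, compound 2 `CCCCc1ccc2[nH]c(-c3ccc(OC)cc3)c(/C=N/NC(=O)c3ccc(F)cc3)c2c1` gives 19 nM and compound 3 `CCCCc1ccc2[nH]c(-c3ccc(OC)cc3)c(/C=N/NC(=O)c3ccncc3)c2c1` gives 29 nM. Compound 3 lies within the scatter of both others: a 1.4-fold lower number from compound 1 to compound 3 (0.14 log units; within the scatter) and a 1.5-fold higher number from compound 2 to compound 3 (0.18 log units; within the scatter). Only a 2.1-fold lower number from compound 1 to compound 2 (0.32 log units; beyond the scatter) goes beyond the scatter, and modestly. Compound 4 `COc1ccc(-c2[nH]c3ccc(C)cc3c2/C=N/NC(=O)c2ccncc2)cc1` changes something else: hydrogen in place of propyl on a saturated chain carbon bound to an aromatic carbon, that is, butyl to methyl. Among the measured compounds shown here, none of the measured steps touches this chain, so they give no direct guide to size or direction. A modest rise in the number is a working guess, and the range stays wide. The estimated step is a 2.1-fold higher number from compound 3 to compound 4 (0.32 log units; beyond the scatter). In this assay, compound 4 is estimated at 60 nM, with an expected range of 15 nM to 250 nM.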

Compound 4, half-maximal inhibitory concentration: 290 nM
Compound 4: the middle estimate sits 4.8-fold (0.68 log units) below what was measured; measured number outside the range, above it.
By their numbers in this assay, from the lowest: compounds 2, 3 and 1 (each within the scatter of the next, the first and the last beyond it); then compound 4.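

In this assay, butyl to methyl gives a 10-fold higher number from compound 3 to compound 4 (1.00 log units; beyond the scatter), a larger step than any change on the double-bonded nitrogen, the largest of which is a 2.1-fold lower number from compound 1 to compound 2 (0.32 log units; beyond the scatter). In this pair, the chain therefore weighs more on the read-out than the group on that nitrogen. No evidence at hand accounts for the step.

With only butyl and methyl at this place, the compounds shown leave open how the number tracks chain length, through ethyl or a longer chain such as hexyl. From the compounds shown here alone, whether a terminal amine on the chain would hold the number also stays open.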